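Ester to aryl ether on the side-chain oxygen

This account rests on a few compounds, and the source may have more. Where it says the series, first, only, none or still open, it means among the compounds named here.

Measured compounds:
compound 1 `COc1nc(C)c(Nc2nc(Cl)cn([C@H](COC(=O)c3cccnc3)C3CC3)c2=O)cc1C` — 5.2 nM
compound 2 `COc1nc(C)c(Nc2nc(Cl)cn([C@H](COC(=O)Nc3ccc(Cl)cc3)C3CC3)c2=O)cc1C` — 1.6 nM

In an assay on frontal cortex for displacement of a labelled ligand from corticotropin-releasing factor receptor 1 (Rattus norvegicus), with a stated time of 2 h (on this read-out higher numbers stand for weaker inhibition and lower numbers for stronger inhibition), compound 1 gives 5.2 nM, the highest of the two numbers recorded. The nearest measured compound is compound 2, reached by a 3.3-fold lower number from compound 1 to compound 2 (0.51 log units; beyond the scatter), where (4-chlorophenyl)amino replaces pyridin-3-yl on a carbonyl carbon; compound 2 gives 1.6 nM.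

Compound 3 `COc1nc(C)c(Nc2nc(Cl)cn([C@H](COc3ccccn3)C3CC3)c2=O)cc1C` differs from compound 1 by pyridin-2-yl in place of (pyridin-3-yl)carbonyl on an oxygen on a saturated carbon. Among the compounds with values here, the one measured step exchanges the group on the carbonyl carbon while keeping the carbonyl; the change to compound 3 removes the carbonyl altogether and puts an aromatic ring directly on the oxygen. Within the data shown here, no measured step therefore bears directly on it. Among the measured compounds shown here, the single step available was modest and beyond the scatter, which shows that this part of the molecule can shift the number, but gives no direction for the present change. The step of a 1.0-fold lower number from compound 1 to compound 3 (0.02 log units; within the scatter) is expected to be small, with no clear direction beyond the scatter. Compound 3 is expected to give 5 nM, with a range from 1.5 nM to 17 nM.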

Compound 3, half-maximal inhibitory concentration: 1.2 nM
Compound 3: middle estimate off by 4.2-fold (0.62 log units), on the high side; the whole stated range lies above it.
By their numbers in this assay, from the lowest: compounds 3 and 2 (each within the scatter of the next); then compound 1.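

In this assay, the carbonyl on the side-chain oxygen proves dispensable: replacing (pyridin-3-yl)carbonyl with pyridin-2-yl turns the ester into an aryl ether and gives a lower number (a 4.3-fold lower number from compound 1 to compound 3 (0.64 log units; beyond the scatter)). The aryl ether also stands level with the carbamate (a 1.3-fold lower number from compound 2 to compound 3 (0.12 log units; within the scatter)), so two groups that differ in whether a carbonyl is present reach the same range on this oxygen, while the pyridin-3-yl ester sits apart from both. No supporting data bear on what lies behind these steps.

Open, from the compounds shown here alone, is whether the ring nitrogen of pyridin-2-yl matters at all: a phenyl ether or a pyridin-3-yl ether on the same oxygen would separate the identity of the ring from the loss of the carbonyl. Also open, going by these compounds, is how much of the ring is needed, which a methyl ether or a free hydroxyl would test, and whether an amine in place of the side-chain oxygen would hold the number in this assay.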